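A Methyl Added Twice: Expecting the Next Step

The source may hold more compounds than are shown below. What is called first, only, known or untested is meant among the compounds shown, and "the series" means these compounds.

Compound 1 `CCNC(=O)c1noc(-c2cc(C(C)C)c(O)cc2O)c1-c1cc(C(=O)NC)no1` gives 100 nM in a functional assay on A2780 cells (Homo sapiens) for inhibition; a lower number here means a stronger inhibitor, a higher number a weaker inhibitor.
Compound 2 `CCNC(=O)c1cc(-c2c(C(=O)NCC)noc2-c2cc(C(C)C)c(O)cc2O)on1` gives 43 nM.
Compound 3 `CCNC(=O)c1noc(-c2cc(C(C)C)c(O)cc2O)c1-c1cnn(CC)c1` gives 30 nM.

Compound 2 differs from compound 1 by methyl in place of hydrogen on a saturated chain carbon bound to an amide-type nitrogen, and that step gave a 2.3-fold lower number from compound 1 to compound 2 (0.37 log units; beyond the scatter). Compound 3 carries a different core; how it differs from compound 1 is 1-ethyl-1H-pyrazol-4-yl in place of 3-(methylcarbamoyl)-1,2-oxazol-5-yl on an aromatic carbon, with a step of a 3.3-fold lower number from compound 1 to compound 3 (0.52 log units; beyond the scatter). Compound 2 and compound 3 are separated by a 1.4-fold lower number from compound 2 to compound 3 (0.16 log units; within the scatter).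

The unmeasured compound 4 `CCNC(=O)c1noc(-c2cc(C(C)C)c(O)cc2O)c1-c1cnn(C(C)C)c1` differs from compound 3 by methyl in place of hydrogen on a saturated chain carbon bound to an aromatic nitrogen and a saturated chain carbon. Among the compounds with values here, this is the same kind of change as the one from compound 1 to compound 2, but not the same change: there the place was a saturated chain carbon bound to an amide-type nitrogen, here it is a saturated chain carbon bound to an aromatic nitrogen and a saturated chain carbon. The step from compound 3 to compound 4 is expected to be a 1.5-fold lower number from compound 3 to compound 4 (0.18 log units; within the scatter), a little smaller and less certain than its counterpart, because the only measured case of this kind gave a 2.3-fold lower number from compound 1 to compound 2 (0.37 log units; beyond the scatter) at a different place. Compound 4 is therefore estimated at 20 nM, expected to fall between 8 nM and 50 nM.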

Compound 4, half-maximal inhibitory concentration: 21 nM
Compound 4: middle estimate off by 1.1-fold (0.02 log units), on the low side; low and high end bracket the measured number.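

Adding the methyl to turn 1-ethyl-1H-pyrazol-4-yl into 1-isopropyl-1H-pyrazol-4-yl gave a 1.4-fold lower number from compound 3 to compound 4 (0.15 log units; within the scatter), a step that cannot be told apart from repeat measurement on its own, while replacing the whole group gave a 2.0-fold lower number from compound 2 to compound 4 (0.31 log units; beyond the scatter) and a 4.8-fold lower number from compound 1 to compound 4 (0.68 log units; beyond the scatter). These two larger steps also include the exchange of the group itself, so they say nothing about the methyl alone. The two methyl steps show no detectable difference between the cores, but two cases at different places do not prove that the change carries over as a rule, and only one of them lies beyond the scatter: the same change on two cores in this assay, a 2.3-fold lower number (0.37 log units; beyond the scatter) from compound 1 to compound 2 and a 1.4-fold lower number (0.15 log units; within the scatter) from compound 3 to compound 4, 1.6-fold (0.21 log units) apart, within the scatter of two such steps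

The compounds shown leave open whether a longer chain, such as n-butyl, or a chain ending in an amine or a carboxylic acid, would continue the same direction in place of the isopropyl. They also leave open how compound 4 behaves in any measurement other than this assay.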